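Replacing the Neopentylphenyl Group with a Nitrophenyl Group

This account rests on a few compounds, and the source may have more. Where it says the series, first, only, none or still open, it means among the compounds named here.

Measured compounds:
compound 1 `CC(C)c1ccc(C2(CNC(=O)Nc3c(C(C)C)cccc3C(C)C)CCCC2)cc1`: 48 nM
compound 2 `CC(C)c1cccc(C(C)C)c1NC(=O)NCC1(c2ccc(CC(C)(C)C)cc2)CCCC1`: 159 nM
compound 3 `CC(C)c1cccc(C(C)C)c1NC(=O)NCC1(c2ccc(Cl)cc2)CCCC1`: 32 nM

In an assay on microsomes for inhibition of acyl-CoA:cholesterol acyltransferase (Oryctolagus cuniculus) (on this read-out lower numbers stand for stronger inhibition and higher numbers for weaker inhibition), compound 2 gives 159 nM, the highest number of the three. The nearest is compound 1 with 48 nM, and a 3.3-fold higher number from compound 1 to compound 2 (0.52 log units; beyond the scatter) is beyond the scatter. The furthest is compound 3 with 32 nM, and a 5.0-fold lower number from compound 2 to compound 3 (0.70 log units; beyond the scatter) is also beyond the scatter.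

Compound 4 `CC(C)c1cccc(C(C)C)c1NC(=O)NCC1(c2cccc([N+](=O)[O-])c2)CCCC1` is not yet measured. It differs from compound 2 by 3-nitrophenyl in place of 4-neopentylphenyl on a saturated ring carbon. The measured steps only bear on it in part: both a 3.3-fold higher number from compound 1 to compound 2 (0.52 log units; beyond the scatter) and a 5.0-fold lower number from compound 2 to compound 3 (0.70 log units; beyond the scatter) show that compound 2, carrying neopentyl, gives the highest number, while smaller groups such as isopropyl or chloro give lower numbers. For the measured compounds named here, no measured compound carries a nitro group, and none carries a substituent at the 3-position of this phenyl ring, so the new group itself is unanchored.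

Compound 4 is therefore expected to give a lower number than compound 2 in this assay, by a 2.7-fold lower number from compound 2 to compound 4 (0.42 log units; beyond the scatter), with wide uncertainty. The estimate for compound 4 is 60 nM, within a range of 15 nM to 250 nM.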

Compound 4, half-maximal inhibitory concentration: 51 nM
Estimate against measurement, compound 4: 1.2-fold (0.07 log units) above, and the stated range covers the measured number.
By their numbers in this assay, from the lowest: compounds 3, 1 and 4 (each within the scatter of the next); then compound 2.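

In this assay, for the compounds shown here, the 3-nitrophenyl group on the saturated ring carbon gives a first reading for a nitro group on this phenyl ring, and the change from 4-neopentylphenyl is a clear one, with a 3.1-fold lower number from compound 2 to compound 4 (0.49 log units; beyond the scatter). Compound 4 cannot be told apart from the two other compounds, with a 1.6-fold higher number from compound 3 to compound 4 (0.20 log units; within the scatter) and a 1.1-fold higher number from compound 1 to compound 4 (0.03 log units; within the scatter), so 3-nitrophenyl reads level with 4-chlorophenyl and 4-isopropylphenyl and, among these four compounds, only compound 2 stands apart. Nothing on hand explains these differences.

The compounds shown do not separate the effect of the nitro group from that of where it sits on the phenyl ring. They also leave open how an amine or a carboxylic acid in place of the nitro group would read in this assay.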